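The compounds below may be only part of what the source reports. "The series", "measured", "known", "first", "only" and "open" are said of these compounds alone.

Three compounds that share a core set the scene in a functional assay on P388 cells (Mus musculus) for inhibition; on this read-out lower numbers stand for stronger inhibition and higher numbers for weaker inhibition. Compound 1 `O=C1/C(=C/c2cccc(Cl)c2)Cc2ccccc21` gives 26300 nM. Compound 3 `Cc1ccc(/C=C2\Cc3ccccc3C2=O)cc1` gives 38600 nM, and these two numbers lie within the usual scatter of each other, so they cannot be ranked. Compound 2 `O=C1/C(=C/c2ccc(Br)cc2)Cc2ccccc21` returns only a limit, > 50000 nM, and not an exact number. Compound 1 therefore stands among weak numbers, level with compound 3 within the scatter.

The next compound to consider is compound 4 `COc1cccc(/C=C2\Cc3ccccc3C2=O)c1`, which has methoxy in place of chloro on an aromatic carbon, meta to a large group: methoxy in place of chloro on an aromatic carbon. Among the compounds with values here, no measured pair makes this exact swap. The closest evidence is another swap of one small group for another on an aromatic carbon, methyl in place of bromo, which gives an at least 1.2-fold lower number from compound 2 to compound 3 (0.11 log units; that floor lies within the scatter). That step rests on a limit, and its floor lies within the scatter, so it offers no sign of a large effect, though it cannot rule one out. No step beyond the scatter is therefore expected in this assay, and no direction can be called with confidence. The expected step is a 1.3-fold higher number from compound 1 to compound 4 (0.10 log units; within the scatter). For compound 4 the estimated value is 33000 nM, with an expected range from 15000 nM to 50000 nM.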

Compound 4, half-maximal inhibitory concentration: > 50000 nM
Compound 4: a limit, no number (the forecaster's own chance of this, stated with the estimate: 20%); middle value at least 1.5-fold (0.18 log units) away from the limit.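

In this assay compound 4 gives > 50000 nM, which is a limit of the assay and not a number. Within the data shown here, putting methoxy in place of chloro on this aromatic carbon, meta to a large group, gives an at least 1.9-fold higher number from compound 1 to compound 4 (0.27 log units; that floor lies within the scatter), so this is the first step read directly at this place, and it shows no gain in inhibition, while how far the true number lies past that floor cannot be read. The limit now recurs across the small set, so this read-out has little room to separate the weaker compounds: the limit of > 50000 nM in this assay, at which 2 of the 4 values shown sit.

The compounds shown leave open whether any group at this place can bring an exact number clearly lower than that of compound 1, which gives 26300 nM. An amine, a carboxylic acid or a longer chain such as ethoxy on the same aromatic carbon would show whether the weak numbers hold for other kinds of group, or whether the swap to methoxy is a special case.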